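A few compounds are considered here, and "the series" means these few. Any claim that something is new, unique, unknown or untested is made for them only; others in the source may bear on it.

Of the compounds shown here, three that share one core have been measured in a functional assay on HL-60 cells (Homo sapiens), with a stated time of 2 days; a higher number here means a weaker inhibitor, a lower number a stronger inhibitor. Compound 1 `O=C(Nc1ccc(Cl)c(Cl)c1)c1nc[nH]c1C(=O)NCc1ccc(Cl)cc1` gives 16200 nM, the highest of the three numbers. Compound 3 `COC(=O)[C@@H](NC(=O)c1[nH]cnc1C(=O)Nc1ccc(Cl)c(Cl)c1)c1ccccc1` gives 13200 nM, a value that sits within the usual scatter of that of compound 1, so the two cannot be told apart. Compound 2 `C[C@@H](NC(=O)c1[nH]cnc1C(=O)Nc1ccc(Cl)c(Cl)c1)C(=O)OC(C)(C)C` gives 4600 nM, and the step of a 3.5-fold lower number from compound 1 to compound 2 (0.55 log units; beyond the scatter) is the only one among these compounds that lies beyond the scatter.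

Compound 4 `CCCN(CCC)C(=O)c1[nH]cnc1C(=O)Nc1ccc(Cl)c(Cl)c1` has not yet been measured. It differs from compound 1 in one place: dipropylamino in place of (4-chlorobenzyl)amino on a carbonyl carbon. Going by the values given here, only one measured step bears on this, a 3.5-fold lower number from compound 1 to compound 2 (0.55 log units; beyond the scatter), which also exchanged the group on that same carbonyl carbon and lowered the number modestly, while compound 3, carrying yet another group there, stayed close to compound 1. Neither of those steps put a dipropylamino group in place, so the record gives no direct guide. The expectation is therefore a number near that of compound 1, with a wide range allowed on either side, and the expected step of a 1.2-fold higher number from compound 1 to compound 4 (0.09 log units; within the scatter) is small. Compound 4 is estimated at 20000 nM in this assay, with a range from 6000 nM to 60000 nM.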

Compound 4, half-maximal inhibitory concentration: 379000 nM
Estimate against measurement, compound 4: 19-fold (1.28 log units) below; measured number above the stated range.
By their numbers in this assay, from the lowest: compound 2; then compounds 3 and 1 (each within the scatter of the next); then compound 4.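

In this assay, the group on this carbonyl carbon can matter far more than compounds 1, 2 and 3 suggested: a 23-fold higher number from compound 1 to compound 4 (1.37 log units; beyond the scatter) is a much larger move than a 3.5-fold lower number from compound 1 to compound 2 (0.55 log units; beyond the scatter), and it runs the other way. Losing the ring of the (4-chlorobenzyl)amino group does not by itself go with a high number, since compound 2 also has no ring in this group and gives 4600 nM, but compound 4 is the only one of the four with no hydrogen on the amide nitrogen at this position. No measurement shown here explains the large rise in the number.

The compounds shown leave open whether the rise goes with the missing amide hydrogen or with the two propyl chains, since dipropylamino brings both at once. A propylamino group, which has a single propyl chain and keeps the amide hydrogen, would help separate the two, and a piperidine amide would show whether tying the chains into a ring changes the outcome.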